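Swapping bromo for methoxy on a weak cell-growth inhibitor

The source may hold more compounds than are shown below. What is called first, only, known or untested is meant among the compounds shown, and "the series" means these compounds.

Of the compounds shown here, three have been tested in a functional assay on HepG2 cells (Homo sapiens) for inhibition, read by MTT assay, with a stated time of 48 h; a higher number here means a weaker inhibitor, a lower number a stronger inhibitor. Compound 1 `O=C(C=CNc1cc(-c2ccccc2)nn1-c1ccccc1)c1ccc(Cl)cc1` gives 41200 nM. Compound 2 `Brc1ccc(-c2ccnc3c2c(-c2ccccc2)nn3-c2ccccc2)cc1` gives 49900 nM, the highest of the three numbers, though its gap to compound 1 lies within the scatter, so the two cannot be ranked against each other. Compound 3 `CN1CCN(c2ccc(-c3c(C#N)c(-c4ccc(Cl)cc4)nc4c3c(-c3ccccc3)nn4-c3ccccc3)cc2)CC1` gives 14600 nM, a number below that of compound 2 by a gap that lies beyond the scatter.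

Compound 4 `COc1ccc(-c2ccnc3c2c(-c2ccccc2)nn3-c2ccccc2)cc1` has not yet been measured in this assay. It differs from compound 2 in one place: methoxy in place of bromo on an aromatic carbon. For the measured compounds named here, nothing in the measured set contains this same swap, so no measured step shows what it does here. The expectation therefore rests only on the fact that compound 2 sits at the weak end of the set and that a single small substituent is exchanged for another small one. The expected step of a 1.1-fold lower number from compound 2 to compound 4 (0.04 log units; within the scatter) is small, with no clear direction beyond the scatter. Compound 4 is estimated to give 45000 nM in this assay, with a range from 15000 nM to 130000 nM.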

Compound 4, half-maximal inhibitory concentration: 6590 nM
For compound 4 the middle estimate is 6.8-fold (0.83 log units) above the measured one; the whole stated range lies above it.
By their numbers in this assay, from the lowest: compound 4; then compound 3; then compounds 1 and 2 (each within the scatter of the next).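

For the compounds shown here, the 4-bromophenyl to 4-methoxyphenyl change gives the first direct reading at this position: in this assay there is a 7.6-fold lower number from compound 2 to compound 4 (0.88 log units; beyond the scatter), a modest step that lies beyond the scatter. The place on the aromatic carbon para to a large group therefore matters for this series, as exchanging one small substituent for another moves the number clearly, although this rests on a single pair of compounds. Methoxy carries a hydrogen-bond acceptor and bromo does not, but that is only a description of the two groups, and no measurement here links this difference to the step or otherwise explains it.

From the compounds shown here alone, the pair cannot separate a gain from adding methoxy from a gain from removing bromo, and it remains open how a plain hydrogen, a hydroxyl, an amine or a longer chain such as ethoxy would read at this place. Going by these compounds, it also remains open whether the same swap would lower the number on a different core, such as the core of compound 3.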